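The source may hold more compounds than are shown below. What is called first, only, known or untested is meant among the compounds shown, and "the series" means these compounds.

Measured in a functional assay on HepG2 cells (Homo sapiens) for cytotoxicity, read by WST assay, with a stated time of 24 h; a lower number here means that less compound is tolerated, a higher number that more compound is tolerated:
- compound 1 `CCCCCCCCCc1cc(-c2ccc3cc(C(=O)O)ccc3c2)ccc1O`: 1.73 ug/mL
- compound 2 `CCCCCCCCCc1cc(-c2ccc3cc(CO)ccc3c2)ccc1O`: 7.25 ug/mL
- compound 3 `CCCC=Cc1cc(-c2ccc3cc(CO)ccc3c2)ccc1O`: 3.89 ug/mL

Compound 1 has the lowest number of the three, so it is the least tolerated by the cells, and compound 3 is its nearest neighbour. The next compound, compound 4 `CCCCCc1cc(-c2ccc3cc(C(=O)O)ccc3c2)ccc1O`, keeps the carboxy group of compound 1 but has a shorter chain: hydrogen in place of butyl on a saturated chain carbon, five bonds along the chain from an aromatic carbon. In words, this is hydrogen in place of butyl on a saturated chain carbon, five bonds along the chain from an aromatic carbon.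

Two measured steps offer some guidance. The step of a 4.2-fold higher number from compound 1 to compound 2 (0.62 log units; beyond the scatter) involves a change elsewhere, hydroxymethyl in place of carboxy, so it says nothing direct about the chain. The closer parallel is a 1.9-fold lower number from compound 2 to compound 3 (0.27 log units; within the scatter), with pent-1-en-1-yl in place of nonyl, but it stays within the scatter and was measured on a hydroxymethyl compound. No step beyond the scatter is therefore expected in this assay, and the expected step is a 1.2-fold lower number from compound 1 to compound 4 (0.06 log units; within the scatter). The estimated value for compound 4 is 1.5 ug/mL, with an expected range of 0.6 ug/mL to 4.5 ug/mL.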

Compound 4, concentration lethal to 50% of the cells: 3.26 ug/mL
Compound 4: middle estimate off by 2.2-fold (0.34 log units), on the low side; the range from low to high includes it.
By their numbers in this assay, from the lowest: compounds 1, 4, 3 and 2 (each within the scatter of the next, the first and the last beyond it).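

This is the first chain change shown with the carboxy group kept and the chain left saturated: in this assay, hydrogen in place of butyl on a saturated chain carbon, five bonds along the chain from an aromatic carbon, gives a 1.9-fold higher number from compound 1 to compound 4 (0.28 log units; within the scatter) and so cannot be told apart from no change. Cells therefore tolerate compound 1 and compound 4 alike within the scatter, even though the chain at this position differs by a butyl group, which extends to the carboxy series what the earlier chain step suggested only for a hydroxymethyl compound with a different, unsaturated chain. Nothing available explains this result.

As far as these compounds go, whether the same holds for much shorter chains, such as methyl or ethyl, remains open. Also open, from the compounds shown here alone, is how an amine in place of the carboxy group would behave with the pentyl chain of compound 4.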